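The source may report more compounds than this note shows. Statements on the series, on what has been measured and on what is new or still open speak of the compounds shown alone.

Measured so far:
- compound 1 `COc1ncnc2c1c(-c1ccsc1)cn2[C@@H]1O[C@H](CO)[C@@H](O)[C@H]1O`: 2570 nM
- compound 2 `COc1nc(N)nc2c1c(-c1ccco1)cn2[C@@H]1O[C@H](CO)[C@@H](O)[C@H]1O`: > 20000 nM

In a functional assay on CCRF-CEM cells (Homo sapiens), read by MTT assay, with a stated time of 72 h (a higher number here means a weaker inhibitor, a lower number a stronger inhibitor), compound 1 gives 2570 nM. Compound 2 gives only a limit in this assay, > 20000 nM, and no number. Among the compounds with values here, compound 2 thus sits at the limit of > 20000 nM in this assay, at which 1 of the 2 values shown sits, the weaker end of the two values shown, while compound 1 is the only compound with a numerical reading.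

Compound 3 `COc1ncnc2c1c(-c1ccco1)cn2[C@@H]1O[C@H](CO)[C@@H](O)[C@H]1O` remains to be measured in this assay. It differs from compound 2 by hydrogen in place of amino on an aromatic carbon. Compound 1 also carries hydrogen at that position and gives a numerical value, whereas compound 2 carries amino there and only a limit; the two also differ in the five-membered ring attached to the core, so the step cannot be separated cleanly.

The step from compound 2 to compound 3 is expected to move toward stronger inhibition, estimated as an at least 4.4-fold lower number from compound 2 to compound 3 (0.64 log units; beyond the scatter). Compound 3 is estimated at 4500 nM, within 1500 nM to 15000 nM.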

Compound 3, half-maximal inhibitory concentration: 20 nM
The estimate for compound 3 lay 230-fold (2.35 log units) above the measured number; measured number outside the range, below it.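

In this assay, the group on the aromatic carbon between two ring nitrogen atoms proves decisive for the furan-2-yl compounds: hydrogen in place of amino gives an at least 1000-fold lower number from compound 2 to compound 3 (3.00 log units; beyond the scatter). Going by these compounds, the true size of that step stays unknown, since compound 2 gives only a limit: the limit of > 20000 nM in this assay, at which 1 of the 3 values shown sits. With hydrogen held at that carbon, the five-membered ring on the core matters as well, and furan-2-yl in place of thiophen-3-yl gives a 130-fold lower number from compound 1 to compound 3 (2.11 log units; beyond the scatter).

Still open, on these data alone, is whether any group other than hydrogen is accepted at that carbon, for example methyl, chlorine or methylamino, or whether the loss seen with amino extends to them. Also open, as far as these compounds go, is whether amino has the same effect with thiophen-3-yl on the core, and how a phenyl ring would compare with furan-2-yl.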